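Extending the ethyl chain of compound 3 to butyl

The compounds below may be only part of what the source reports. "The series", "measured", "known", "first", "only" and "open" are said of these compounds alone.

Values in a functional assay on cells (Platelet, Homo sapiens) for inhibition (a higher number here means a weaker inhibitor, a lower number a stronger inhibitor), are given below, each of them a limit of the assay and not a number
- compound 1 `CCOC(=O)c1ccc(-c2nn(Cc3ccc(Cl)cc3)c3ccccc23)cc1` gives > 10000 nM as a limit
- compound 2 `CCOC(=O)c1ccc(-c2nn(Cc3ccc(OC)cc3)c3ccccc23)cc1` gives > 10000 nM as a limit
- compound 3 `CCOC(=O)c1ccc(-c2nn(CC)c3ccccc23)cc1` gives > 10000 nM as a limit

Compound 3 therefore stands on a limit only, and the same holds across the series, with the limit of > 10000 nM in this assay, at which 3 of the 3 values shown sit, as the whole of the evidence. No ranking can be drawn from it.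

Compound 4 `CCCCn1nc(-c2ccc(C(=O)OCC)cc2)c2ccccc21` keeps the shared core and changes only the chain, which runs to butyl instead of ethyl. The difference is ethyl in place of hydrogen on a saturated chain carbon, two bonds along the chain from an aromatic nitrogen.

Among the measured compounds shown here, two measured steps touch this chain, a step that the two limits leave unreadable from compound 1 to compound 3 and a step that the two limits leave unreadable from compound 2 to compound 3, and neither has a readable size. None of the three groups tried here brought a number into this assay, so no step beyond the scatter is expected and no direction can be given. The estimated step is a step that the limit leaves unreadable from compound 3 to compound 4 and it is expected to remain unreadable in practice. For compound 4 the estimated value is 15000 nM, with an expected range from 6000 nM to 40000 nM and a limit the likeliest report.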

Compound 4, half-maximal inhibitory concentration: > 10000 nM
Compound 4: a limit, no number (the forecaster's own chance of this, stated with the estimate: 85%); the middle value is on the limit's open side.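

In this assay compound 4 gives > 10000 nM, a limit of the assay and not a number. No step from compound 4 to compound 1, compound 2 or compound 3 can be read, because the series rests on one limit: the limit of > 10000 nM in this assay, at which 4 of the 4 values shown sit.

The compounds shown leave open whether any group on this chain of the shared core gives a number in this assay.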